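The source may report more compounds than this note shows. Statements on the series, on what has been measured and on what is new or still open speak of the compounds shown alone.

Within the data shown here, compound 2 `COc1ccc(OC)c(/C=C/C(=O)N2CCN(Cc3nc(C)c(C)nc3C)CC2)c1` is the only compound of this set with a number: in a functional assay on ECV-304 cells (Homo sapiens), with stated times of 30 min and 6 h (on this read-out higher numbers stand for an effect only at larger amounts of compound and lower numbers for an effect already at smaller amounts), compound 2 gives 376000 nM. Compound 1 `Cc1nc(C)c(CN2CCN(C(=O)C(C)(C)Oc3ccc(Cl)cc3)CC2)nc1C`, which shares the core, gives "not determined" (no result reported) in this assay, so compound 2 cannot be placed against any other measured compound. Compound 3 `COc1ccc(/C=C/C(=O)N2CCN(Cc3nc(C)c(C)nc3C)CC2)cc1OC` is the next step, and its change from compound 2 is 3,4-dimethoxyphenyl in place of 2,5-dimethoxyphenyl on a double-bonded chain carbon bound to a double-bonded chain carbon; the two have the same atoms, joined differently. Among the measured compounds shown here, no step between measured compounds is available to judge what such a rearrangement of the two methoxy groups does in this assay. With nothing to go on but the weak half-maximal effective concentration of compound 2, a step of no more than the usual scatter is expected in either direction, and the estimated step of a 1.1-fold lower number from compound 2 to compound 3 (0.03 log units; within the scatter) is set accordingly. Compound 3 is therefore expected to give 350000 nM, within a range from 120000 nM to 1000000 nM.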

Compound 3, half-maximal effective concentration: 282000 nM
For compound 3 the middle estimate is 1.2-fold (0.09 log units) above the measured one; the measured number falls inside the stated range.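

In this assay, among these compounds, the swap of 2,5-dimethoxyphenyl for 3,4-dimethoxyphenyl on a double-bonded chain carbon bound to a double-bonded chain carbon gives a 1.3-fold lower number from compound 2 to compound 3 (0.12 log units; within the scatter), the only step between measured compounds here. The two arrangements of the methoxy groups therefore cannot be told apart on this read-out, and for this pair the placement of the two methoxy groups makes no difference beyond the usual scatter. Nothing in the data shown offers an explanation for this result.

From the compounds shown here alone, what stays open is whether any other group at this place would give a step beyond the scatter, such as a phenyl carrying an amine or a carboxylic acid instead of the methoxy groups. Going by these compounds, whether a longer chain between this aromatic ring and the carbonyl would matter also remains open.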